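The source may report more compounds than this note shows. Statements on the series, on what has been measured and on what is new or still open speak of the compounds shown alone.

Measured so far:
Compound 1 `O=S(=O)(NCC1CCN(CCCc2c[nH]c3ccc(-n4cnnc4)cc23)CC1)c1ccccc1`: 6.2 nM
Compound 2 `C[C@@H](NCC1CCN(CCCc2c[nH]c3ccc(-n4cnnc4)cc23)CC1)c1ccccc1`: 1.4 nM

In an assay on CHO cells for displacement of a labelled ligand from 5-hydroxytryptamine receptor 1D (Homo sapiens) (on this read-out lower numbers stand for stronger inhibition and higher numbers for weaker inhibition), compound 2 holds the lower of the two numbers shown, and the only measured step, a 4.4-fold lower number from compound 1 to compound 2 (0.65 log units; beyond the scatter), separates it from compound 1. Compound 3 `O[C@H]1Cc2ccccc2C1NC1CCN(CCCc2c[nH]c3ccc(-n4cnnc4)cc23)CC1` has not yet been measured in this assay. It differs from compound 2 at a single place: (2-hydroxy-2,3-dihydro-1H-inden-1-yl)amino in place of ((1-phenylethyl)amino)methyl on a saturated ring carbon. Among the compounds with values here, the one step on record varies the group carried by the amine, as this change does, and both measured compounds give low numbers, so the region tolerates different groups; yet no measured pair exchanges a chain for a ring or brings in a hydroxyl, so no step of this kind is known. Compound 3 is therefore expected to stay in the same low range, with a 2.1-fold higher number from compound 2 to compound 3 (0.33 log units; beyond the scatter) as a tentative guess. The estimate for compound 3 is 3 nM, within 0.7 nM to 15 nM.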

Compound 3, half-maximal inhibitory concentration: 37 nM
Beside the measured number, compound 3's estimate is 12-fold (1.09 log units) below it; measured number above the stated range.
By their numbers in this assay, from the lowest: compound 2; then compound 1; then compound 3.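

In this assay, this saturated ring carbon proves less forgiving than compound 1 and compound 2 suggested: the change to (2-hydroxy-2,3-dihydro-1H-inden-1-yl)amino gives a 26-fold higher number from compound 2 to compound 3 (1.42 log units; beyond the scatter), a large step. Set against the ((phenylsulfonyl)amino)methyl group, the same change gives a 6.0-fold higher number from compound 1 to compound 3 (0.78 log units; beyond the scatter), so compound 3 stands above both earlier compounds and the low numbers do not hold for every group tried at this position. Nothing in the data explains this rise.

As far as these compounds go, the change alters several features at once, so it remains open whether the hydroxyl, the closed five-membered ring or the loss of the methylene carries the step. Two groups could separate these features: plain 2,3-dihydro-1H-inden-1-ylamino, which lacks the hydroxyl, and ((2-hydroxy-1-phenylethyl)amino)methyl, which keeps the open chain.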